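This account rests on a few compounds, and the source may have more. Where it says the series, first, only, none or still open, it means among the compounds named here.

In a physicochemical assay for solubility, in phosphate buffer, measured as kinetic solubility, with a stated time of 24 h, at pH 7.4 (on this read-out higher numbers stand for higher solubility and lower numbers for lower solubility), compound 1 `COC1CCN(c2ccc(CN(CC(C)C)S(=O)(=O)Cc3ccccc3)cc2)CC1` reads <= 1000 nM, which is a limit and not a number. Compound 2 `CC(=O)N1CCN(c2ccc(CN(CC(C)C)S(=O)(=O)Cc3ccccc3)cc2)CC1` reads <= 1000 nM, also a limit. Compound 3 `CC(=O)N1CCN(c2ccc(CN(C(C)C)S(=O)(=O)Cc3ccccc3)cc2)CC1` reads <= 1000 nM, again a limit. Within the data shown here, the whole series so far therefore stands at one reading: the limit of <= 1000 nM in this assay, at which 3 of the 3 values shown sit. Compound 4 `CC(=O)N1CCN(c2ccc(CN(CCN(C)C)S(=O)(=O)Cc3ccccc3)cc2)CC1` carries 2-(dimethylamino)ethyl in place of isopropyl on a sulfonamide nitrogen. The closest measured change is a step that the two limits leave unreadable from compound 2 to compound 3, made on that same nitrogen, and the other is a step that the two limits leave unreadable from compound 1 to compound 2, so neither offers a size to carry over. An upward move is expected, though only as a loose judgement, and the estimated step is an at least 4.0-fold higher number from compound 3 to compound 4 (0.60 log units; beyond the scatter). The estimate for compound 4 is 4000 nM, with an expected range of 700 nM to 40000 nM.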

Compound 4, solubility: 221000 nM
Compound 4: middle estimate off by 55-fold (1.74 log units), on the low side; the whole stated range lies below it.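

Among these compounds, on the sulfonamide nitrogen, 2-(dimethylamino)ethyl in place of isopropyl gives the first readable step in this assay, an at least 220-fold higher number from compound 3 to compound 4 (2.34 log units; beyond the scatter). Set against the isobutyl chain, the same group gives an at least 220-fold higher number from compound 2 to compound 4 (2.34 log units; beyond the scatter). The steps among the earlier compounds could not be read, and the series had shown only one reading: the limit of <= 1000 nM in this assay, at which 3 of the 4 values shown sit.

On these data alone, what stays open is whether the dimethylamino nitrogen itself is needed for a step of this size. A 2-methoxyethyl group, a carboxylic acid or a longer chain ending in an amine on this nitrogen could settle that.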